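The compounds below may be only part of what the source reports. "The series", "measured", "known", "first", "only" and "open" are said of these compounds alone.

Measured in an ADME assay on SH-SY5Y cells (Homo sapiens) for cytotoxicity, read by MTT assay, with a stated time of 72 h; a higher number here means that more compound is tolerated, a lower number that less compound is tolerated:
Compound 1 `c1coc(-c2ccc3nc(-c4ccco4)cn3c2)c1`: 3000 nM
Compound 2 `Nc1cccn2cc(-c3ccco3)nc12`: > 100000 nM

Compound 2 gives no number, only a limit: it stands at the limit of > 100000 nM in this assay, at which 1 of the 2 values shown sits. Compound 3 `Nc1cc(-c2ccco2)cn2cc(-c3ccco3)nc12` is not yet measured. It is compound 2 with furan-2-yl in place of hydrogen on an aromatic carbon, (furan-2-yl in place of hydrogen on an aromatic carbon). Among the compounds with values here, no measured pair of compounds isolates this change, so the expectation rests on little. Within the data shown here, the only number available comes from compound 1, which also bears two furan-2-yl groups and gives 3000 nM. On that basis, compound 3 is expected to be tolerated less well than compound 2 in this assay, by a clear margin beyond the scatter. The expected step of an at least 10-fold lower number from compound 2 to compound 3 (1.00 log units; beyond the scatter) is a rough estimate, since it starts from a limit. For compound 3 the estimated value is 10000 nM, with an expected range of 2500 nM to 50000 nM.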

Compound 3, half-maximal cytotoxic concentration: 2270 nM
Beside the measured number, compound 3's estimate is 4.4-fold (0.64 log units) above it; measured number below the stated range.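

In this assay, furan-2-yl in place of hydrogen on an aromatic carbon, meta to an amino group and two atoms from the ring nitrogen, gives an at least 44-fold lower number from compound 2 to compound 3 (1.64 log units; beyond the scatter). Compound 2 gives a limit and not a number, so that step is only a floor: the limit of > 100000 nM in this assay, at which 1 of the 3 values shown sits.

Amino in place of hydrogen on an aromatic carbon, by contrast, gives a 1.3-fold lower number from compound 1 to compound 3 (0.12 log units; within the scatter), so with this furan-2-yl present the amino group brings no change that can be told apart from the scatter.

The compounds shown leave open whether this step belongs to furan-2-yl as such or would also follow a phenyl ring, a methyl group or a carboxylic acid at this position. They also leave open whether a furan-3-yl group here would give a step of like size.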